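The source may hold more compounds than are shown below. What is called first, only, known or untested is meant among the compounds shown, and "the series" means these compounds.

The measured compounds in this assay:

compound 1 `c1ccc(COc2ccccc2Nc2ncnc3cc4c(cc23)OCCOCCO4)cc1`, value > 100000 nM
compound 2 `c1ccc(COc2ccc(Nc3ncnc4cc5c(cc34)OCCOCCOCCO5)cc2)cc1`, value > 100000 nM
compound 3 `FC(F)(F)c1ccc(COc2ccc(Nc3ncnc4cc5c(cc34)OCCOCCOCCO5)cc2)cc1`, value 30700 nM

All three were tested in a functional assay on A549 cells (Homo sapiens) for antiproliferative activity, read by MTT assay, with a stated time of 72 h; a higher number here means a weaker inhibitor, a lower number a stronger inhibitor. For compound 1 the value > 100000 nM is a limit of the assay, not a number. For compound 2 the value > 100000 nM is likewise a limit. Compound 3, in contrast, gives a measured number, 30700 nM. Compound 3 differs from compound 2 in one place: trifluoromethyl in place of hydrogen on an aromatic carbon. That change brought an at least 3.2-fold lower number from compound 2 to compound 3 (0.51 log units; beyond the scatter). The true size of this step is open, since the starting value is only (the limit of > 100000 nM in this assay, at which 2 of the 3 values shown sit).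

Compound 4 `FC(F)(F)c1ccc(COc2ccccc2Nc2ncnc3cc4c(cc23)OCCOCCO4)cc1` has not yet been measured. It carries the same change against compound 1 that compound 3 carries against compound 2: trifluoromethyl in place of hydrogen on an aromatic carbon. How the core of compound 1 differs from the core of compound 2 is not broken down here.

Among the compounds with values here, what to expect from compound 1 to compound 4 is estimated as an at least 2.5-fold lower number from compound 1 to compound 4 (0.39 log units; beyond the scatter), resting on an at least 3.2-fold lower number from compound 2 to compound 3 (0.51 log units; beyond the scatter) as the one measured example of this change. Since compound 1 sits at the limit, the starting point for compound 4 is itself unknown, so the estimate is wide. Compound 4 is expected to give about 40000 nM in this assay, with a likely range from 12000 nM to 130000 nM.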

Compound 4, half-maximal inhibitory concentration: > 100000 nM
Compound 4 gave a limit, no number (the forecaster's own chance of this, stated with the estimate: 40%); middle value at least 2.5-fold (0.39 log units) away from the limit.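

Compound 1 and compound 4 both stop at a limit of the assay rather than a number, so no step can be read between them: the limit of > 100000 nM in this assay, at which 3 of the 4 values shown sit.

The compounds shown leave open whether trifluoromethyl changes the activity at all on the core of compound 1, and how large the true values of compound 1 and compound 4 are.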